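Adding a Methyl to Compound 1's Hydroxy

A few compounds are considered here, and "the series" means these few. Any claim that something is new, unique, unknown or untested is made for them only; others in the source may bear on it.

Measured in a functional assay on A549 cells (Homo sapiens) for inhibition, read by MTT assay, with a stated time of 72 h; a higher number here means a weaker inhibitor, a lower number a stronger inhibitor:
- compound 1 `CO[C@@H]1[C@H]2OC(=O)C[C@H]2O[C@@H]1[C@@H](O)c1ccccc1`: 38300 nM
- compound 2 `O=C1C[C@H]2O[C@H](C(O)O)[C@H](O)[C@H]2O1`: 21000 nM
- compound 3 `CO[C@@H]1[C@H]2OC(=O)C[C@H]2O[C@@H]1[C@H](O)c1ccccc1`: 23600 nM

Compound 1 (38300 nM) stands level with the other two compounds, since all three values lie within the usual scatter of one another. The next compound to be tested, compound 4 `CO[C@@H]1[C@H]2OC(=O)C[C@H]2O[C@@H]1[C@@H](OC)c1ccccc1`, turns hydroxy to methoxy, with methyl in place of hydrogen on an oxygen on a saturated carbon. Among the measured compounds shown here, only one measured step bears on this change, and only indirectly: a 1.6-fold lower number from compound 1 to compound 3 (0.21 log units; within the scatter). There, (the fact that compounds 1 and 3 differ only in the configuration as drawn), and the hydroxy stays in place, so this step shows a change in configuration without a measurable effect but does not test the methyl. For the measured compounds named here, with no measured step on that group, a shift in either direction remains possible, and no change beyond the scatter is expected in this assay. The expected step is a 1.4-fold lower number from compound 1 to compound 4 (0.14 log units; within the scatter). For compound 4 the estimated value is 28000 nM, with an expected range from 10000 nM to 70000 nM.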

Compound 4, half-maximal inhibitory concentration: 25100 nM
Beside the measured number, compound 4's estimate is 1.1-fold (0.05 log units) above it, and the stated range covers the measured number.
By their numbers in this assay, from the lowest: compounds 2, 3, 4 and 1 (each within the scatter of the next).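

In this assay, among the compounds shown here, this is the first direct reading of the change at this oxygen: a 1.5-fold lower number from compound 1 to compound 4 (0.18 log units; within the scatter). Methyl in place of hydrogen on an oxygen on a saturated carbon therefore leaves the number within the scatter, so for this one small group, the hydroxy hydrogen can be replaced without a shift this assay can distinguish. The earlier step at this part of the molecule could not show this, since it altered the drawn configuration and kept the hydroxy: the fact that compounds 1 and 3 differ only in the configuration as drawn

Still open, from the compounds shown here alone, is whether something larger on this oxygen, such as a longer chain or an acetyl ester, or an amine in place of the hydroxy, would move the number beyond the scatter. Also open, going by these compounds, is whether the same methyl gives a similar result on the configuration of compound 3.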